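The source may report more compounds than this note shows. Statements on the series, on what has been measured and on what is new or still open speak of the compounds shown alone.

Measured compounds:
compound 1 `COc1ccc(-c2nc(SCC(=O)c3sc(-c4ccccc4)nc3C)nc(N)c2C#N)cc1`, 60.8%
compound 2 `COc1ccc(-c2nc(SCC(=O)c3sc(-c4ccccc4)nc3C)[nH]c(=O)c2C#N)cc1`, 90.4%
compound 3 `COc1ccc(-c2nc(C)c(C(=O)CSc3nc(-c4ccc(OC)cc4)c(C#N)c(=O)[nH]3)s2)cc1`, 80.3%

In a functional assay on U-87MG ATCC cells for antiproliferative activity against U-87 MG (Homo sapiens), read by MTT assay, with a stated time of 48 h, tested at 10 uM (a higher number here means a weaker effect of the compound at the concentration tested, a lower number a stronger effect), compound 2 gives 90.4%, the highest of the three numbers; compound 3 stands nearest, separated by the step of a number 10.1 percentage points lower from compound 2 to compound 3 (beyond the scatter), while compound 1 lies furthest below it. Compound 4 `COc1cccc(-c2nc(SCC(=O)c3sc(-c4ccccc4)nc3C)[nH]c(=O)c2C#N)c1` has not been measured and differs from compound 2 in one place: 3-methoxyphenyl in place of 4-methoxyphenyl on an aromatic carbon. For the measured compounds named here, no measured step bears directly on this change; the only measured step, a number 10.1 percentage points lower from compound 2 to compound 3 (beyond the scatter), concerns methoxy in place of hydrogen on another ring and was modest. On this basis no step beyond the scatter is expected in this assay, the expected step being a number 4.4 percentage points lower from compound 2 to compound 4 (within the scatter). Compound 4 is therefore estimated at 86%, within the range 70% to 100%.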

Compound 4, a percentage reported as activity, at one concentration (the size of the read-out at that concentration, not a potency): 90.2%
Compound 4: the middle estimate sits 4.2 percentage points below what was measured; low and high end bracket the measured number.
By their numbers in this assay, from the lowest: compound 1; then compounds 3, 4 and 2 (each within the scatter of the next, the first and the last beyond it).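

In this assay, for the compounds shown here, the shift from 4-methoxyphenyl to 3-methoxyphenyl gives a number 0.2 percentage points lower from compound 2 to compound 4 (within the scatter), the first step at this position, on the aromatic carbon ortho to a cyano group. Here, moving the methoxy around the phenyl ring leaves no readable mark on the number, whereas the earlier step concerned a methoxy on another ring. Nothing measured here offers an explanation for this. From the compounds shown here alone, whether a chlorine or a hydroxyl on this ring would read differently stays open. So does whether the same shift would behave alike on the core of compound 1.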